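A few compounds are considered here, and "the series" means these few. Any claim that something is new, unique, unknown or untested is made for them only; others in the source may bear on it.

Across this small set the shared core of compound 1 carries two 3-hydroxyphenyl groups and one further aromatic group, and it is that third group that varies. Among the compounds with values here, compound 1 `Oc1cccc(-c2cc(-c3cccs3)cc(-c3cccc(O)c3)n2)c1` is the only member with a result: in an assay on isolated protein for inhibition of DNA topoisomerase 1 (Homo sapiens), with a stated time of 30 min, tested at 20 uM (a higher number here means a stronger effect of the compound at the concentration tested, a lower number a weaker effect), compound 1 gives 0%. Compound 2 `Oc1cccc(-c2cc(-c3ccccn3)cc(-c3cccc(O)c3)n2)c1` carries a pyridin-2-yl group in its place, but in this assay compound 2 gives "not determined" (no result reported), so compound 2 stands without a number of its own. Within the data shown here, compound 3 `Oc1cccc(-c2cc(-c3cccnc3)cc(-c3cccc(O)c3)n2)c1` follows from compound 2 by one rearrangement: pyridin-3-yl in place of pyridin-2-yl on an aromatic carbon No step between measured compounds is available for this change. Because compound 1 gives 0% in this assay, the step to compound 3 in this assay is expected to stay within the scatter, in no direction. Compound 3 is therefore expected to give 5% in this assay, within 0% to 20%.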

Compound 3, a percentage reported as inhibition, at one concentration (the size of the read-out at that concentration, not a potency): 1.9%
Estimate against measurement, compound 3: 3.1 percentage points above; low and high end bracket the measured number.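

Compound 3 gives this position a second number, and with it the first readable step: in this assay, pyridin-3-yl in place of thiophen-2-yl gives a number 1.9 percentage points higher from compound 1 to compound 3 (within the scatter), so these two aromatic groups cannot be told apart here and both compounds sit near the bottom of the read-out. Compound 2 has no number, so its steps to compound 1 and compound 3 cannot be read, and the shift from pyridin-2-yl to pyridin-3-yl remains without a result. No supporting evidence bears on why the read-out stays this low.

The compounds shown leave open whether anything other than an aromatic ring at this position, such as an amine, a carboxylic acid or a longer chain, would give a larger read-out. They also leave open what the two 3-hydroxyphenyl groups contribute, since both are the same throughout.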